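A few compounds are considered here, and "the series" means these few. Any claim that something is new, unique, unknown or untested is made for them only; others in the source may bear on it.

Of the compounds shown here, two have been measured in an assay on Sf9 cells for inhibition of protein deacetylase HDAC6 (Homo sapiens), read by fluorescence, with a stated time of 40 min, tested at 100 nM; a lower number here means less inhibition, a higher number more inhibition at the concentration tested (going by the name of the read-out). Compound 1, `O=C(NO)c1ccc(NCc2nc(-c3cccc4cnccc34)nn2-c2ccccc2)cc1`, gives 40.2% there, the lowest of the two numbers. Compound 2, `O=C(NO)c1ccc(NCc2nc(-c3ccccc3)nn2-c2ccc(F)cc2)cc1`, gives 67.6% in this assay, a number higher than that of compound 1 by more than the usual scatter. Going by the values given here, compound 2 differs from compound 1 in more than one place, so the two values show only that the pair lies apart; no single change links them.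

Compound 3, `Cc1cccc(-c2nc(CNc3ccc(C(=O)NO)cc3)n(-c3ccccc3)n2)c1`, is not yet measured in this assay. Its change from compound 1 is 3-methylphenyl in place of isoquinolin-5-yl on an aromatic carbon. Compound 2 also carries a phenyl group on that aromatic carbon of the shared core and gives the higher value, 67.6%, which hints that a plain benzene-type ring in this place goes with a higher number in this assay. The expected step of a number 16.8 percentage points higher from compound 1 to compound 3 (beyond the scatter) is therefore upward and of moderate size, though with the scatter it could also turn out flat. Compound 3 is estimated at 57%, with a range from 35% to 78%.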

Compound 3, a percentage reported as inhibition, at one concentration (the size of the read-out at that concentration, not a potency): 64.1%
Estimate against measurement, compound 3: 7.1 percentage points below; low and high end bracket the measured number.
By their numbers in this assay, from the lowest: compound 1; then compounds 3 and 2 (each within the scatter of the next).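

In this assay, going by these compounds alone, replacing isoquinolin-5-yl with 3-methylphenyl on the aromatic carbon between two ring nitrogen atoms gives a number 23.9 percentage points higher from compound 1 to compound 3 (beyond the scatter), the first comparison here in which only one place differs. It shows that the read-out responds to what this carbon carries, at least for this pair of groups, which the earlier two compounds could not show because they differ in more than one place. The change swaps a two-ring group containing a ring nitrogen for a single carbon-only ring with a methyl group, so ring count, size and the hydrogen-bond acceptor all change together, and no information at hand separates these or explains the step.

As far as these compounds go, what the methyl group itself contributes remains open, since a one-place comparison of 3-methylphenyl with plain phenyl on this same core would be needed to separate it from the loss of the second ring. Also open, from the compounds shown here alone, is how this position would respond to other groups, such as a methoxy group, an amine or a carboxylic acid on the benzene ring, or to a non-aromatic ring such as cyclohexyl.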